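Taking the tert-butoxy group off compound 3

The source may hold more compounds than are shown below. What is called first, only, known or untested is meant among the compounds shown, and "the series" means these compounds.

In a functional assay on A-431 cells (Homo sapiens) for inhibition, read by MTT assay, with a stated time of 72 h (a lower number here means a stronger inhibitor, a higher number a weaker inhibitor), three compounds have been measured: compound 1 `Cc1ccc(-c2nnc(SCCCN3CCN(c4nc5ccccc5s4)CC3)o2)cc1` (61600 nM), compound 2 `Brc1ccc(-c2nnc(SCCCN3CCN(c4nc5ccccc5s4)CC3)o2)cc1` (51600 nM) and compound 3 `CC(C)(C)Oc1ccc(-c2nnc(SCCCN3CCN(c4nc5ccccc5s4)CC3)o2)cc1` (67000 nM). All three lie within the usual scatter of one another, so compound 3 stands level with the other two. Compound 4 `c1ccc(-c2nnc(SCCCN3CCN(c4nc5ccccc5s4)CC3)o2)cc1` has hydrogen in place of tert-butoxy on an aromatic carbon and is still to be measured. Two measured steps at the same place bear on it (a 1.3-fold higher number from compound 2 to compound 3 (0.11 log units; within the scatter)) and (a 1.1-fold higher number from compound 1 to compound 3 (0.04 log units; within the scatter)), and both are within the scatter. Among the compounds with values here, no measured compound has hydrogen there, so the range stays wide. No change beyond the scatter is expected in this assay for this swap. The expected step is small (a 1.2-fold lower number from compound 3 to compound 4 (0.06 log units; within the scatter)) with no firm direction. Compound 4 is estimated at 58000 nM with 30000 nM to 100000 nM as the expected range.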

Compound 4, half-maximal inhibitory concentration: 93400 nM
Estimate against measurement, compound 4: 1.6-fold (0.21 log units) below; the measured number falls inside the stated range.
By their numbers in this assay, from the lowest: compounds 2, 1, 3 and 4 (each within the scatter of the next).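

In this assay, hydrogen at this position gives no step beyond the scatter against tert-butoxy (a 1.4-fold higher number from compound 3 to compound 4 (0.14 log units; within the scatter)), bromo (a 1.8-fold higher number from compound 2 to compound 4 (0.26 log units; within the scatter)) or methyl (a 1.5-fold higher number from compound 1 to compound 4 (0.18 log units; within the scatter)). Even with no substituent there, then, the four compounds stay level, so among these groups neither the size of the group nor its presence at this position shows any effect on the number. No measurement is available to explain this level result.

From the compounds shown here alone, whether an amine or a carboxylic acid at this position would shift the number stays open. So does whether a longer chain in the shared core would.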